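Hydroxyphenyl Position Shift: Cytotoxicity Working Notes

This account rests on a few compounds, and the source may have more. Where it says the series, first, only, none or still open, it means among the compounds named here.

Measured compounds:
- compound 1, `Oc1cccc(-c2cc(-c3ccc(Cl)cc3)nc(-c3cccs3)c2)c1`: 11800 nM
- compound 2, `Oc1ccc(-c2cc(-c3ccc(Cl)cc3)nc(-c3cccs3)c2)cc1`: 4520 nM
- compound 3, `Oc1ccc(-c2cc(-c3ccccc3)nc(-c3cccc(Cl)c3)c2)cc1`: 2820 nM

In an ADME assay on HEK293 cells (Homo sapiens) for cytotoxicity, read by CCK-8 assay and cell counting, with a stated time of 2 days (a lower number here means a stronger inhibitor, a higher number a weaker inhibitor), compound 3 gives 2820 nM, the lowest number of the three measured compounds; compound 2 gives 4520 nM and is within the scatter of compound 3, while compound 1 gives 11800 nM and stands beyond it. The difference between the cores of compound 2 and compound 3 is not broken down here.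

One change is seen twice. From compound 2 to compound 1 the change is 3-hydroxyphenyl in place of 4-hydroxyphenyl on an aromatic carbon, and it made a 2.6-fold higher number from compound 2 to compound 1 (0.42 log units; beyond the scatter) in this assay. The unmeasured compound 4, `Oc1cccc(-c2cc(-c3ccccc3)nc(-c3cccc(Cl)c3)c2)c1`, differs from compound 3 by 3-hydroxyphenyl in place of 4-hydroxyphenyl on an aromatic carbon. The place is the same kind: on an aromatic carbon of a six-membered aromatic ring with 1 nitrogen, opposite the ring nitrogen; but in compound 3 it is meta to a 3-chlorophenyl group and meta to a phenyl group, whereas in compound 2 it is meta to a 4-chlorophenyl group and meta to a thiophen-2-yl group. The change is therefore the same kind of change, not the same.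

For the measured compounds named here, with only one earlier instance, the step expected from compound 3 to compound 4 is taken to be about as large as the earlier one: a 2.5-fold higher number from compound 3 to compound 4 (0.39 log units; beyond the scatter) is the estimate, resting on compound 2 to compound 1 having made a 2.6-fold higher number from compound 2 to compound 1 (0.42 log units; beyond the scatter). Compound 4 is thus expected to give about 7000 nM in this assay, with a range from 3300 nM to 15000 nM.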

Compound 4, half-maximal inhibitory concentration: 3120 nM
Compound 4: the middle estimate sits 2.2-fold (0.35 log units) above what was measured; measured number below the stated range.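

In this assay, 3-hydroxyphenyl in place of 4-hydroxyphenyl gives a 1.1-fold higher number from compound 3 to compound 4 (0.04 log units; within the scatter), so on this core the two numbers cannot be told apart. Taken alone, the earlier step lay beyond the scatter and this one within it, but the gap between them does not establish a difference between the two cores: the same change on two cores in this assay, a 2.6-fold higher number (0.42 log units; beyond the scatter) from compound 2 to compound 1 and a 1.1-fold higher number (0.04 log units; within the scatter) from compound 3 to compound 4, 2.4-fold (0.37 log units) apart, within the scatter of two such steps. Two steps therefore show neither that the change carries from one core to another with a fixed size nor that its size depends on the core, and they give no basis for using the earlier step alone as a firm estimate on a new core.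

The compounds shown leave open how the same change behaves on a third core, and whether the 4-chlorophenyl and thiophen-2-yl groups of the core of compound 2, or the 3-chlorophenyl and phenyl groups of the core of compound 3, have any separate bearing on its size, since these groups differ together. Also open, as far as these compounds go, is what happens when an amine or a carboxylic acid takes the place of the hydroxyl group on the same ring.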